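Cyano for methyl on the five-membered ring of compound 3

This account rests on a few compounds, and the source may have more. Where it says the series, first, only, none or still open, it means among the compounds named here.

Compound 3 `Cc1cnn(C(=O)CCCCCc2ccccc2)c1` stands, in an assay on isolated protein for inhibition of Fatty-acid amide hydrolase 1 (Rattus norvegicus), with a stated time of 3 h (a higher number here means a weaker inhibitor, a lower number a stronger inhibitor), at > 5000 nM; this is a limit of the assay and not a number. Compound 2 `O=C(CCCCCc1ccccc1)n1cccn1` likewise returns only a limit, > 5000 nM. Compound 1 `CC(C)(C)OC(=O)N1CCN(C(=O)n2cc(C#N)cn2)CC1`, which carries a cyano on the same kind of ring but a different acyl part, gives 55 nM. Two of the three values shown sit at the limit of > 5000 nM in this assay, at which 2 of the 3 values shown sit.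

The step from compound 3 to compound 4 `N#Cc1cnn(C(=O)CCCCCc2ccccc2)c1` is cyano in place of methyl on an aromatic carbon. Within the data shown here, the one measured step at this ring position, a step that the two limits leave unreadable from compound 2 to compound 3, gives no readable size, as both of its ends sit at the limit of > 5000 nM in this assay, at which 2 of the 3 values shown sit. Among the measured compounds shown here, no measured step connects a methyl-bearing to a cyano-bearing member of the series with the same acyl part; compound 1 shows only that a cyano-bearing member can reach 55 nM.

Compound 4 is therefore expected in this assay at about 1500 nM, within 200 nM to 6000 nM. The expected step is an at least 3.3-fold lower number from compound 3 to compound 4 (0.52 log units; beyond the scatter), toward stronger inhibition, with a real chance that only a limit is returned again.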

Compound 4, inhibition constant: > 5000 nM
Compound 4 was reported as a limit (the forecaster's own chance of this, stated with the estimate: 35%); middle value at least 3.3-fold (0.52 log units) away from the limit.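

Compound 4 returns only a limit in this assay, > 5000 nM, and not a number, so no step among compound 2, compound 3 and compound 4 can be read: the limit of > 5000 nM in this assay, at which 3 of the 4 values shown sit.

The compounds shown leave open how hydrogen, methyl and cyano on this ring rank when the acyl part stays the same.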